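Alkoxymethylamino series: methoxymethyl to ethoxymethyl step

The compounds below may be only part of what the source reports. "The series", "measured", "known", "first", "only" and "open" are said of these compounds alone.

Compound 1 `O=[N+]([O-])c1cccc(COCNc2n[n+]([O-])c3ccccc3[n+]2[O-])c1`: 16600 nM
Compound 2 `COCNc1n[n+]([O-])c2ccccc2[n+]1[O-]`: 9070 nM

In a functional assay on KB cells (Homo sapiens) for cytotoxicity, read by MTT assay, with a stated time of 72 h (on this read-out higher numbers stand for weaker inhibition and lower numbers for stronger inhibition), compound 2 gives 9070 nM, the lower of the two numbers shown, though compound 1 with 16600 nM sits within the scatter of it, so no real order can be read. Compound 3 `CCOCNc1n[n+]([O-])c2ccccc2[n+]1[O-]` differs from compound 2 by methyl in place of hydrogen on a saturated chain carbon bound to an oxygen on a saturated carbon, methoxy to ethoxy when cut one bond further out. For the measured compounds named here, no step between measured compounds is at hand to size such a change; in this assay a small step is expected, in either direction, none beyond the scatter. Compound 3 is therefore estimated at 8000 nM, range 3500 nM to 18000 nM. The step of a 1.1-fold lower number from compound 2 to compound 3 (0.05 log units; within the scatter) is expected to stay inside the scatter.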

Compound 3, half-maximal inhibitory concentration: 22500 nM
Estimate against measurement, compound 3: 2.8-fold (0.45 log units) below; the measured number lies above the stated range.
By their numbers in this assay, from the lowest: compounds 2, 1 and 3 (each within the scatter of the next, the first and the last beyond it).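

In this assay, for the compounds shown here, methyl in place of hydrogen on a saturated chain carbon bound to an oxygen on a saturated carbon gives a 2.5-fold higher number from compound 2 to compound 3 (0.39 log units; beyond the scatter) and so sizes, for the first time, a change at this position. The methoxymethyl to ethoxymethyl step is modest but not silent, and it runs toward weaker inhibition. No measurement shown accounts for this step. As far as these compounds go, whether a longer chain such as propoxymethyl extends the shift remains open, as does the effect of an amine at the chain end.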